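The source may hold more compounds than are shown below. What is called first, only, known or untested is meant among the compounds shown, and "the series" means these compounds.

Working notes on the series. Compound 1 `Cc1ccc2c(c1)C(=O)/C(=C/c1ccc(Br)cc1)CN2CC(=O)O` carries a 4-bromophenyl group on the shared core and gives in an assay on HL-60 cells for inhibition of glutathione S-transferase P (Homo sapiens), read by spectrophotometry, tested at 20 uM (a lower number here means less inhibition, a higher number more inhibition at the concentration tested (going by the name of the read-out)), a value of 28.2%. This is the highest of the three measured numbers. Compound 2 `COc1ccc(OC)c(/C=C2\CN(CC(=O)O)c3c(C)cccc3C2=O)c1` gives 5.44% in this assay, and compound 3 `COc1cccc(/C=C2\CN(CC(=O)O)c3c(C)cccc3C2=O)c1OC` gives 8.1% in this assay; both of these values lie beyond the usual scatter below that of compound 1, with compound 3 the nearer and compound 2 the further of the two. Among the compounds with values here, both lower compounds carry methoxy-substituted aryl groups in place of the bromophenyl, though they differ from compound 1 in more than one place, so no single-change step is available among the measured compounds.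

Compound 4 `COc1ccc(/C=C2\CN(CC(=O)O)c3ccc(C)cc3C2=O)cc1` has not yet been measured. It differs from compound 1 in one place: methoxy in place of bromo on an aromatic carbon. Within the data shown here, no measured pair shows this exact step. Going by the two methoxy-bearing compounds, compound 2 with 5.44% and compound 3 with 8.1%, both well below compound 1, a move downward beyond the scatter is expected in this assay, estimated as a number 14.2 percentage points lower from compound 1 to compound 4 (beyond the scatter). Compound 4 is thus expected to give about 14% in this assay, in an estimated range from 3% to 30%.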

Compound 4, a percentage reported as inhibition, at one concentration (the size of the read-out at that concentration, not a potency): 17.5%
Compound 4: the middle estimate sits 3.5 percentage points below what was measured; the measured number falls inside the stated range.
By their numbers in this assay, from the lowest: compounds 2, 3 and 4 (each within the scatter of the next, the first and the last beyond it); then compound 1.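

In this assay, within the data shown here, the change from 4-bromophenyl to 4-methoxyphenyl on the shared core can now be read on its own, as a number 10.7 percentage points lower from compound 1 to compound 4 (beyond the scatter), and this modest step is the first direct reading at this position. Among these compounds, the earlier methoxy-bearing compounds differ from compound 1 in more than one place, so they could not separate this change from the others, whereas this pair shows that the single exchange lowers the number without taking it to nothing, with compound 4 still at 17.5% in this assay. Nothing available explains the step, so only its size and direction can be stated.

The compounds shown leave open whether a different group at this position, such as an amine, a nitrile or a carboxylic acid, would give a number nearer to that of compound 1 or further from it. Among the compounds shown here, they also leave open whether the same exchange gives a step of similar size on other versions of the core, since this single pair is the only reading of it, and a value at one concentration gives no potency.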